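The compounds below may be only part of what the source reports. "The series", "measured", "known", "first", "only" and "open" are said of these compounds alone.

Working notes on the series in a functional assay on C8166 cells (Homo sapiens) for cytotoxicity, read by MTT assay; a higher number here means that more compound is tolerated, a lower number that less compound is tolerated. Compound 1 `Cc1cc(S(N)(=O)=O)ccc1NC(=O)COc1ccc(Cl)cc1NC(=O)c1cccc(F)c1` gives 243000 nM, compound 2 `Cc1cc(S(N)(=O)=O)ccc1NC(=O)COc1ccc(Cl)cc1NC(=O)c1cccc([N+](=O)[O-])c1` gives 58800 nM and compound 3 `Cc1cc(S(N)(=O)=O)ccc1NC(=O)COc1ccc(Cl)cc1NC(=O)c1cccc(C(F)(F)F)c1` gives 124000 nM. Compound 3 holds the middle place of these three numbers, with two steps setting its position: a 2.0-fold lower number from compound 1 to compound 3 (0.29 log units; within the scatter), and a 2.1-fold higher number from compound 2 to compound 3 (0.32 log units; beyond the scatter). It therefore cannot be separated from compound 1 but does stand clear of compound 2.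

Compound 4 `Cc1cc(S(N)(=O)=O)ccc1NC(=O)COc1ccc(Cl)cc1NC(=O)c1cc(Cl)ccc1Cl` carries 2,5-dichlorophenyl in place of 3-(trifluoromethyl)phenyl on a carbonyl carbon. The measured steps bear on this change only indirectly. Going by the values given here, all of them exchange fluoro, nitro and trifluoromethyl at this end of the molecule, and no measured compound has a 2,5-dichlorophenyl group. The largest of them is a 4.1-fold lower number from compound 1 to compound 2 (0.62 log units; beyond the scatter), which is modest, and the data give no direction for the new group. A change of about that size at most is expected in this assay, and most likely none beyond the scatter. The expected move is a 1.1-fold lower number from compound 3 to compound 4 (0.05 log units; within the scatter). For compound 4 the estimated value is 110000 nM, with an expected range from 45000 nM to 260000 nM.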

Compound 4, half-maximal cytotoxic concentration: 42100 nM
For compound 4 the middle estimate is 2.6-fold (0.42 log units) above the measured one, and the stated range ends above it.
By their numbers in this assay, from the lowest: compounds 4 and 2 (each within the scatter of the next); then compounds 3 and 1 (each within the scatter of the next).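

In this assay, the 2,5-dichlorophenyl group on the carbonyl carbon gives a direction that the fluoro, nitro and trifluoromethyl compounds could not give for it: less compound is tolerated (a 2.9-fold lower number from compound 3 to compound 4 (0.47 log units; beyond the scatter)), and the step from the fluoro compound is larger still (a 5.8-fold lower number from compound 1 to compound 4 (0.76 log units; beyond the scatter)). Going by these compounds alone, the same group cannot be separated from the 3-nitrophenyl group (a 1.4-fold lower number from compound 2 to compound 4 (0.15 log units; within the scatter)), so the four compounds fall into two groups at this position, with compounds 4 and 2 on the lower side and compounds 3 and 1 on the higher side, and no compound goes against this split. No supporting measurement bears on why the number moves with this change.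

The compounds shown leave open whether a single chloro on the phenyl ring would give the same step as the two chlorines of the 2,5-dichlorophenyl group. They also leave open how this assay responds when this phenyl ring carries an amine or a carboxylic acid, since every substituent so far is a halogen, nitro or trifluoromethyl.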